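A few compounds are considered here, and "the series" means these few. Any claim that something is new, unique, unknown or untested is made for them only; others in the source may bear on it.

Compound 2 `Nc1ncnc2c1nc(NCc1ccccc1Cl)n2[C@@H]1O[C@H](CO)[C@@H](O)[C@H]1O` is the only one of the three measured compounds to give a number in an assay on COS-7 cells for inhibition of sodium/nucleoside cotransporter 2 (Homo sapiens), read by scintillation counting, in the presence of a further agent that is not named here; a higher number here means a weaker inhibitor, a lower number a stronger inhibitor: 5700 nM. Compound 1 `Nc1ncnc2c1ncn2[C@@H]1O[C@H](COC(=O)OCc2ccccc2)[C@@H](O)[C@H]1O` gives only a limit of the assay, > 100000 nM. Compound 3 `CCCCCC(=O)OC[C@H]1O[C@@H](n2cnc3c(N)ncnc32)[C@H](O)[C@@H]1O` likewise gives only a limit, > 100000 nM. The step that the two limits leave unreadable from compound 1 to compound 3 rests on the limit of > 100000 nM in this assay, at which 2 of the 3 values shown sit, and concerns a different place in the molecule. Compound 4 `Cc1ccccc1CNc1nc2c(N)ncnc2n1[C@@H]1O[C@H](CO)[C@@H](O)[C@H]1O` differs from compound 2 by methyl in place of chloro on an aromatic carbon. Among the measured compounds shown here, no measured step touches this place, so no shift beyond the scatter is expected in this assay. Compound 4 is thus expected at 6000 nM, with a range from 2000 nM to 20000 nM. The expected step is a 1.1-fold higher number from compound 2 to compound 4 (0.02 log units; within the scatter), within the scatter.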

Compound 4, half-maximal inhibitory concentration: 65000 nM
For compound 4 the middle estimate is 11-fold (1.03 log units) below the measured one; measured number above the stated range.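

Methyl in place of chloro on an aromatic carbon, ortho to a large group, gives an 11-fold higher number from compound 2 to compound 4 (1.06 log units; beyond the scatter) in this assay, so this place responds strongly to the exchange of one heavy atom for another. Among the compounds shown here, the earlier compounds gave no readable step at this place: their one step cannot be read and concerns a different place in the molecule. Of this pair, the (2-chlorobenzyl)amino compound, compound 2, is the stronger inhibitor.

On these data alone, whether bromo, methoxy or an unsubstituted benzyl would follow chloro or methyl stays open. Nothing shown bears on why this change has so large an effect.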